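The source may hold more compounds than are shown below. What is called first, only, known or untested is meant among the compounds shown, and "the series" means these compounds.

Of the compounds shown here, three have been measured in an ADME assay on MT4 cells (Homo sapiens) for cytotoxicity, read by MTT assay, with a stated time of 96 h (a higher number here means that more compound is tolerated, a lower number that less compound is tolerated), so far. Compound 1 (`Clc1cccc(/N=N/N2CCCC2)c1`) shows > 100000 nM as a limit of the assay and not a number. Compound 2 (`Fc1ccc(F)c(/N=N/c2ccc(NC[C@@H]3CCCN4CCCC[C@H]34)c3c2CCCC3)c1`) gives 40000 nM and compound 3 (`c1ccc(/N=N/N2CCN(c3ccccc3)CC2)cc1`) gives 33000 nM and these two numbers lie within the scatter of each other. Compound 2 therefore stands level with compound 3 on the numbers available.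

The next compound is compound 4 (`c1ccc(/N=N/c2ccc(NC[C@@H]3CCCN4CCCC[C@H]34)c3c2CCCC3)cc1`), which carries phenyl in place of 2,5-difluorophenyl on a double-bonded nitrogen. Among the measured compounds shown here, no measured pair of compounds shows this change, so the data give no direct size or direction for it. In this assay no step beyond the scatter is expected, and the expectation stays anchored on compound 2 at 40000 nM as the closest measured structure. The estimated step is a 1.1-fold lower number from compound 2 to compound 4 (0.02 log units; within the scatter) and it stays within the scatter. For compound 4 the estimated value is 38000 nM with an expected range from 16000 nM to 90000 nM in this measurement.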

Compound 4, half-maximal cytotoxic concentration: 100000 nM
The estimate for compound 4 lay 2.6-fold (0.42 log units) below the measured number; the measured number lies above the stated range.
By their numbers in this assay, from the lowest: compounds 3 and 2 (each within the scatter of the next); then compound 4.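

In this assay, among the compounds shown here, the earlier compounds offered no pair differing in one place, so this is the first step that can be read for the group on a double-bonded nitrogen: a 2.5-fold higher number from compound 2 to compound 4 (0.40 log units; beyond the scatter). It shows that exchanging 2,5-difluorophenyl for phenyl at this position, with the rest of the structure unchanged, moves the number upward by a modest step beyond the scatter. Compound 1 is recorded only as a limit and not as a number, and compound 4 reaches the same figure, which places it at the top of the range reported: the limit of > 100000 nM in this assay, at which 1 of the 4 values shown sits.

This single pair cannot show whether one fluorine, a chlorine or a methoxy group in this place would give a number closer to compound 2 or to compound 4. Compound 1 and compound 3 differ from this pair in more than one place, so they cannot show whether the step holds on another core.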